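This account rests on a few compounds, and the source may have more. Where it says the series, first, only, none or still open, it means among the compounds named here.

Compound 1 `N#Cc1cnc(NCc2cnccc2C(F)(F)F)cc1NC[C@H]1CC[C@@H](O)CC1` gives 500 nM in an assay on isolated protein for inhibition of protein kinase C delta type (Homo sapiens), read by TR-FRET, with a stated time of 2 h; a lower number here means a stronger inhibitor, a higher number a weaker inhibitor. Compound 2 `CO[C@H]1CC[C@H](CNc2cc(NCc3cnccc3C(F)(F)F)ncc2C#N)CC1` gives only a limit of this assay, > 10000 nM.

In this assay compound 2 thus sits at a limit, not at a number (the limit of > 10000 nM in this assay, at which 1 of the 2 values shown sits). The change to compound 3 `N#Cc1cnc(NCc2cnccc2C(F)(F)F)cc1NC1CCOCC1` is oxan-4-yl in place of (4-methoxycyclohexyl)methyl on a nitrogen on an aromatic ring. Within the data shown here, the only measured step touching this part of the molecule is an at least 20-fold higher number from compound 1 to compound 2 (1.30 log units; beyond the scatter), a large loss when the hydroxy group became a methoxy group. Compound 3 carries no hydroxy group either, yet its shorter oxan-4-yl group differs from both. The estimate for compound 3 is 3000 nM, expected between 600 nM and 15000 nM, which means an at least 3.3-fold lower number from compound 2 to compound 3 (0.52 log units; beyond the scatter).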

Compound 3, half-maximal inhibitory concentration: 9800 nM
For compound 3 the middle estimate is 3.3-fold (0.51 log units) below the measured one; low and high end bracket the measured number.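

In this assay, the change to oxan-4-yl gives a 20-fold higher number from compound 1 to compound 3 (1.29 log units; beyond the scatter), so a second replacement of (4-hydroxycyclohexyl)methyl also ends far weaker, and only compound 1 keeps a hydroxy group. The other step reads only an at least 1.0-fold lower number from compound 2 to compound 3 (0.00 log units; that floor lies within the scatter), so that pair cannot be put in order. Its starting value is a limit, not a number: the limit of > 10000 nM in this assay, at which 1 of the 3 values shown sits.

Still open, on these data alone, is whether the hydroxy group alone accounts for the higher number of compound 1. An amine or a carboxylic acid in place of that hydroxy group would test how specific this position is.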